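This account rests on a few compounds, and the source may have more. Where it says the series, first, only, none or still open, it means among the compounds named here.

In an ADME assay on the whole organism (Mus musculus, strain Swiss Webster) for pharmacokinetics, read by LC-MS, at a dose of 50 mg/kg by the oral route (a higher number here means more compound in the circulation at the dose given, a lower number less compound in the circulation), compound 3 `O=C(Nc1ccc(F)c(-c2nc3ncc(-c4cccc(F)c4F)cc3[nH]2)c1)N1CCCC1` gives 1830 nM and stands level with compound 2 `O=C(Nc1ccc(F)c(-c2nc3ncc(-c4cc(F)ccc4F)cc3[nH]2)c1)N1CCCC1` at 2800 nM (a 1.5-fold lower number from compound 2 to compound 3 (0.18 log units; within the scatter)) while compound 1 `O=C(Nc1ccc(F)c(-c2nc3ncc(-c4ccc(F)c(F)c4)cc3[nH]2)c1)N1CCCC1` at 6670 nM lies clearly higher (a 3.6-fold lower number from compound 1 to compound 3 (0.56 log units; beyond the scatter)).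

The next analogue is compound 4 `O=C(Nc1ccc(F)c(-c2nc3ncc(-c4ccccc4F)cc3[nH]2)c1)N1CCCC1`, which differs from compound 3 at one place (hydrogen in place of fluoro on an aromatic carbon) with hydrogen in place of fluoro on an aromatic carbon, ortho to a fluoro group, so that 2,3-difluorophenyl becomes 2-fluorophenyl.

Within the data shown here, no measured step removes a fluoro group, since all three compare difluorophenyl isomers, so the evidence is indirect. The closest guide is the pair that shares the 2-fluoro group of compound 4 (a 1.5-fold lower number from compound 2 to compound 3 (0.18 log units; within the scatter)). The larger steps (a 2.4-fold lower number from compound 1 to compound 2 (0.38 log units; beyond the scatter) and a 3.6-fold lower number from compound 1 to compound 3 (0.56 log units; beyond the scatter)) both start from the 3,4-difluorophenyl of compound 1, a pattern that compound 4 does not share, and they are only modest. A small step is therefore expected in this assay, most likely within the scatter and with no firm direction, and the estimate is (a 1.3-fold higher number from compound 3 to compound 4 (0.10 log units; within the scatter)) on present data. A modest move either way cannot be excluded.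

Compound 4 is expected at 2300 nM within an estimated range of 950 nM to 5500 nM for now.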

Compound 4, maximal plasma concentration: 2230 nM
Beside the measured number, compound 4's estimate is 1.0-fold (0.01 log units) above it, and the stated range covers the measured number.
By their numbers in this assay, from the lowest: compounds 3, 4 and 2 (each within the scatter of the next); then compound 1.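

Among these compounds, compound 4 gives the first step in which a fluoro group leaves the ring rather than moving around it, and in this assay the loss of either second fluoro group cannot be told from no change (a 1.2-fold higher number from compound 3 to compound 4 (0.09 log units; within the scatter); a 1.3-fold lower number from compound 2 to compound 4 (0.10 log units; within the scatter)). The 2-fluorophenyl, 2,3-difluorophenyl and 2,5-difluorophenyl compounds therefore form one level group, so a fluoro group ortho to the 2-fluoro group, as in compound 3, adds nothing readable here, while the 3,4-difluorophenyl of compound 1 remains apart, though only modestly (a 3.0-fold lower number from compound 1 to compound 4 (0.48 log units; beyond the scatter)). No measurement shown explains these numbers.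

The compounds shown leave open whether the 2-fluoro group shared by compounds 2, 3 and 4 has any effect of its own, which an unsubstituted phenyl would test, and whether the higher number of compound 1 would survive with only one of its two fluoro groups, as in 3-fluorophenyl or 4-fluorophenyl. They also leave open how this position would respond to a group other than fluoro, such as methoxy, nitrile or an amine.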